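Permeability Limits Across Four Related Compounds

The source may hold more compounds than are shown below. What is called first, only, known or untested is meant among the compounds shown, and "the series" means these compounds.

Compound 1 `CNC(=O)c1cc(Oc2ccc3nc(Nc4ccccc4Br)ncc3c2)ccn1`: < 1 10^-6 cm/s
Compound 2 `CCc1ccccc1Nc1ncc2cc(Oc3ccnc(C(=O)NC)c3)ccc2n1`: < 1 10^-6 cm/s
Compound 3 `CNC(=O)c1cc(Oc2ccc3nc(Nc4ccc(C(F)(F)F)cc4)ncc3c2)ccn1`: < 1 10^-6 cm/s

Of the compounds shown here, three built on a shared core have been tested in an ADME assay on Caco-2 cells (Homo sapiens) for permeability, in the apical to basolateral direction; a higher number here means that the compound crosses the layer faster, a lower number that the compound crosses the layer more slowly. Compound 1 gives < 1 10^-6 cm/s, which is a limit of the assay rather than a number. Compound 2 likewise gives < 1 10^-6 cm/s, again a limit. Compound 3 gives < 1 10^-6 cm/s, also a limit. Because of this, (the limit of < 1 10^-6 cm/s in this assay, at which 3 of the 3 values shown sit), none of the three steps among them can be read: a step that the two limits leave unreadable from compound 1 to compound 2, a step that the two limits leave unreadable from compound 1 to compound 3 and a step that the two limits leave unreadable from compound 2 to compound 3 all stay hidden beneath the same limit.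

Compound 4 `CNC(=O)c1cc(Oc2ccc3nc(Nc4ccc(C(C)C)cc4)ncc3c2)ccn1` has not yet been measured. Its difference from compound 1 is 4-isopropylphenyl in place of 2-bromophenyl on a nitrogen on an aromatic ring. The measured steps that replace the 2-bromophenyl group, including the move to 4-(trifluoromethyl)phenyl in compound 3, bear on this change, but their sizes are not readable. For the measured compounds named here, with every value so far sitting at the limit, the expectation is that compound 4 will also sit at or near it, and the step is estimated as a step that the limit leaves unreadable from compound 1 to compound 4. Compound 4 is therefore expected to give about 0.8 10^-6 cm/s, within a range of 0.3 10^-6 cm/s to 3 10^-6 cm/s.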

Compound 4, apparent permeability: < 1 10^-6 cm/s
Compound 4: no number, only a limit (the forecaster's own chance of this, stated with the estimate: 70%); the middle value does not contradict the limit.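

In this assay compound 4 gives < 1 10^-6 cm/s and this is a limit of the assay, not a number. The steps from compound 4 to compound 1, compound 2 and compound 3 therefore cannot be read, because all four compounds share the same limit: the limit of < 1 10^-6 cm/s in this assay, at which 4 of the 4 values shown sit.

The compounds shown leave open whether the group on the nitrogen changes the permeability of this series at all.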